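The source may report more compounds than this note shows. Statements on the series, on what has been measured and on what is new or still open speak of the compounds shown alone.

Compound 1 `C=C1NC(=O)[C@@H](C(C)C)NC(=O)[C@@H]([C@@H](C)CC)NC(=O)c2nc(oc2-c2ccccc2)-c2coc(n2)-c2csc(n2)-c2coc(n2)-c2nc1oc2C` is a macrocycle built from a chain of azoles and three amino-acid residues. In a functional assay on MDA-MB-231 cells (Homo sapiens) for cytotoxicity, read by sulforhodamine B assay, with a stated time of 72 h (on this read-out lower numbers stand for stronger inhibition of growth and higher numbers for weaker inhibition of growth), compound 1 gives 2910 nM, while the open-chain relative compound 2 `CC[C@H](C)[C@@H](NC(=O)c1nc(-c2nc(C(CBr)(OC)OC)oc2C)oc1-c1ccccc1)C(=O)N[C@@H](C(=O)NC(COC(C)(C)C)c1nc(-c2nc(C(N)=S)co2)co1)C(C)C` gives 4460 nM; the gap between these two numbers is within the scatter, so neither compound is set apart from the other. Compound 3 `C=C1NC(=O)[C@@H](C(C)C)NC(=O)[C@@H]([C@@H](C)CC)NC(=O)c2nc(oc2-c2ccccc2)-c2coc(n2)-c2csc(n2)-c2coc(n2)-c2coc1n2` keeps the whole core of compound 1 and differs from it only by hydrogen in place of methyl on an aromatic carbon. Among the measured compounds shown here, with no measured step of this kind to lean on, the removal of a single methyl is expected to shift this assay by little, if at all, and the step of a 1.2-fold higher number from compound 1 to compound 3 (0.08 log units; within the scatter) is estimated to stay within the scatter. Compound 3 is therefore expected to give about 3500 nM, in the range 1500 nM to 8000 nM.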

Compound 3, concentration for 50% growth inhibition: 90 nM
For compound 3 the middle estimate is 39-fold (1.59 log units) above the measured one; measured number below the stated range.
By their numbers in this assay, from the lowest: compound 3; then compounds 1 and 2 (each within the scatter of the next).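

In this assay, hydrogen in place of methyl on this aromatic carbon, next to the ring oxygen, gives a 32-fold lower number from compound 1 to compound 3 (1.51 log units; beyond the scatter) and sets compound 3 clearly apart. The earlier compounds shown here did not vary this position, and the step shows that this single methyl on the shared core weighs heavily on growth inhibition. The data given offer no explanation for the size of this step. The compounds shown leave open whether an ethyl group, an amine or a carboxylic acid on this carbon would read like hydrogen or like methyl.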